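Bromo in place of dimethylamino on the shared core

The source may hold more compounds than are shown below. What is called first, only, known or untested is meant among the compounds shown, and "the series" means these compounds.

Compound 1 `CN(C)c1nc(N)c2ncn([C@@H]3C[C@@H](O)[C@H](CO)O3)c2n1` is the starting point of this note. In a functional assay on PHA-Ly cells (Homo sapiens) (a higher number here means a weaker inhibitor, a lower number a stronger inhibitor), compound 1 gives > 300 uM, and that figure is a limit of the assay, not a number. Compound 1 therefore stands at the weak end of the series (the limit of > 300 uM in this assay, at which 1 of the 3 values shown sits). Two further compounds on the same sugar carry other groups on the core. Compound 3 `CN(C)c1nc(Br)nc2c1ncn2[C@@H]1C[C@@H](O)[C@H](CO)O1` gives 88 uM in this assay. Compound 2 `CSc1nc(SC)c2ncn([C@@H]3C[C@@H](O)[C@H](CO)O3)c2n1` gives 167 uM in this assay. Compound 4 `Nc1nc(Br)nc2c1ncn2[C@@H]1C[C@@H](O)[C@H](CO)O1` has not been measured; it differs from compound 1 by bromo in place of dimethylamino on an aromatic carbon. Among the compounds with values here, no measured pair differs in exactly this way, so the size of the step is not fixed by the data. Compound 3, which also carries bromo on its core, sits inside the measured range with 88 uM. Compound 1, by contrast, sits at the limit. The expected step, an at least 600-fold lower number from compound 1 to compound 4 (2.77 log units; beyond the scatter), is estimated to point toward stronger inhibition, well beyond the scatter. For compound 4 the expected value in this assay is 0.5 uM, with a range from 0.05 uM to 10 uM.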

Compound 4, concentration for 50% inhibition: 1.6 uM
The estimate for compound 4 lay 3.2-fold (0.51 log units) below the measured number; low and high end bracket the measured number.
By their numbers in this assay, from the lowest: compound 4; then compounds 3 and 2 (each within the scatter of the next). At a limit, above all of these: compound 1.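

In this assay compound 1 stands at a limit of the assay and not at a number: the limit of > 300 uM in this assay, at which 1 of the 4 values shown sits. With the amino group kept, bromo in place of dimethylamino between two ring nitrogen atoms gives an at least 180-fold lower number from compound 1 to compound 4 (2.27 log units; beyond the scatter), so this position responds strongly to the change, although the true size of the step cannot be fixed from a limit. With bromo kept, amino in place of dimethylamino on the other aromatic carbon gives a 55-fold lower number from compound 3 to compound 4 (1.74 log units; beyond the scatter), so the low number of compound 4 is lost on either single change back, and among these three compounds it appears only where bromo and amino occur together.

As far as these compounds go, whether bromo itself is needed between the two ring nitrogen atoms stays open, as chloro, iodo or a plain hydrogen at that carbon would test it. From the compounds shown here alone, it also stays open how the series responds to a methylamino group in place of the amino group, which would sit in size between the two groups compared here.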